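Cinnamamide series: alkyl amides against pak choi growth

The compounds below may be only part of what the source reports. "The series", "measured", "known", "first", "only" and "open" are said of these compounds alone.

Measured compounds:
compound 1 `CCCCCCNC(=O)/C=C/c1ccccc1` in a functional assay on the whole organism for inhibition, with Brassica rapa subsp. chinensis as the target, with a stated time of 3 days, tested at 100 ppm; on this read-out higher numbers stand for more inhibition of growth at the one concentration tested and lower numbers for less inhibition of growth: 55%
compound 2 `CCCCCNC(=O)/C=C/c1ccccc1` in this assay: 60%
compound 3 `CC(C)NC(=O)/C=C/c1ccccc1` in this assay: 39%

Compounds 1 and 2 carry straight chains on the amide nitrogen and lie within the scatter of each other: a number 5 percentage points lower from compound 2 to compound 1 (within the scatter), the change being (methyl in place of hydrogen on a saturated chain carbon, five bonds along the chain from an amide-type nitrogen). Compound 3 carries a branched group and stands lowest of the three, with both other values beyond the scatter from it; the difference of cores is isopropyl in place of pentyl on an amide-type nitrogen, giving a number 21 percentage points lower from compound 2 to compound 3 (beyond the scatter).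

The unmeasured compound 4 `CC(C)(C)NC(=O)/C=C/c1ccccc1` differs from compound 3 by methyl in place of hydrogen on a saturated chain carbon bound to an amide-type nitrogen and two saturated chain carbons. This is the same kind of change as from compound 2 to compound 1, not the same: there the methyl enters on a saturated chain carbon five bonds along the chain from an amide-type nitrogen, here on a saturated chain carbon bound to an amide-type nitrogen and two saturated chain carbons. Within the data shown here, only one example of the change is measured, and it sat within the scatter.

For compound 4 a step of a number 4 percentage points lower from compound 3 to compound 4 (within the scatter) is expected, resting on the small step from compound 2 to compound 1 a number 5 percentage points lower from compound 2 to compound 1 (within the scatter) and on the low starting point of compound 3 39%. Compound 4 is estimated at 35%, within 20% to 50%.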

Compound 4, percent growth inhibition at one concentration: 34%
For compound 4 the middle estimate is 1 percentage points above the measured one; the measured number falls inside the stated range.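

Carrying methyl in place of hydrogen onto the core of compound 3, on a saturated chain carbon bound to an amide-type nitrogen and two saturated chain carbons, gives a number 5 percentage points lower from compound 3 to compound 4 (within the scatter) in this assay, and the two examples of the change agree: the same change on two cores in this assay, a number 5 percentage points lower (within the scatter) from compound 2 to compound 1 and a number 5 percentage points lower (within the scatter) from compound 3 to compound 4, 0 percentage points apart, within the scatter of two such steps

At these two places, one on a straight chain and one on a branched group, the added methyl therefore stays within the scatter on both cores. This does not show that the change would stay as small at other places or on other cores, and two steps of this kind fix neither a true size nor a direction for it.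

Going by these compounds, the larger step belongs to the whole group on the nitrogen: tert-butyl in place of pentyl on an amide-type nitrogen gives a number 26 percentage points lower from compound 2 to compound 4 (beyond the scatter), and whether chain length or branching carries it stays open, which a straight propyl or butyl chain on the nitrogen could help to separate. Also open, on these data alone, are how a longer chain, or an amine or a carboxylic acid at the end of the chain, would read in this assay.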